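The compounds below may be only part of what the source reports. "The series", "measured", "known", "first", "only" and "open" are said of these compounds alone.

Measured compounds:
- Compound 1 `O=C(Nc1ncc(Cc2cc3sccc3s2)s1)C1CCCCC1` — in an ADME assay on P388D1 cells (Mus musculus) for cytotoxicity, read by fluorescence and resazurin assay, with a stated time of 72 h (a lower number here means a stronger inhibitor, a higher number a weaker inhibitor), compound 1 gives "not determined" (no result reported).
- Compound 2 `O=C(CCC1CCCCC1)Nc1ncc(Cc2cccc3ccoc23)s1` — in this assay compound 2 gives 17800 nM.

Within the data shown here, compound 2 holds the only number here; compound 1 was tested in the same setting but no single value was reported for it, so compound 2 cannot be ranked against anything. Its value is a high one, meaning weak cytotoxicity toward these mouse cells.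

Compound 3 `O=C(Nc1ncc(Cc2cccc3ccoc23)s1)C1CCCCC1` differs from compound 2 in one place: cyclohexyl in place of 2-cyclohexylethyl on a carbonyl carbon. The amide chain is thus shortened, while the shared core and the aromatic part on the other side are kept unchanged. Among the measured compounds shown here, with no measured pair showing what such a shortening does in this assay, the expectation rests on the structural change alone, and a step of a size within the usual scatter, in either direction, seems most likely, as a step of a 1.1-fold higher number from compound 2 to compound 3 (0.05 log units; within the scatter) expresses.

Compound 3 is therefore expected to give about 20000 nM in this assay, within a range from 6000 nM to 60000 nM.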

Compound 3, half-maximal inhibitory concentration: > 40000 nM
Compound 3 was reported as a limit (the forecaster's own chance of this, stated with the estimate: 25%); middle value at least 2.0-fold (0.30 log units) away from the limit.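

Among these compounds, this is the first one-place change with a readable result: with cyclohexyl in place of 2-cyclohexylethyl on a carbonyl carbon, this assay shows an at least 2.2-fold higher number from compound 2 to compound 3 (0.35 log units; beyond the scatter). The group on this carbonyl carbon therefore matters for the read-out, with the shorter group going with weaker cytotoxicity toward these mouse cells, although one pair cannot establish a trend. The step is only a minimum, because the result for compound 3 is a limit and not a number: the limit of > 40000 nM in this assay, at which 1 of the 3 values shown sits.

Compound 1 has no reported result and so offers no second comparison. From the compounds shown here alone, it remains open whether a longer chain, such as 3-cyclohexylpropyl, would bring a lower number in this assay, and what an amine or a carboxylic acid on the cyclohexyl ring would do.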